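A few compounds are considered here, and "the series" means these few. Any claim that something is new, unique, unknown or untested is made for them only; others in the source may bear on it.

Compound 3 `CNC(=O)c1ccc(Oc2cccc(NC(=S)Nc3ccc(OC)cc3)c2)nc1` gives 85300 nM in a functional assay on HepG2 cells (Homo sapiens) for antiproliferative activity, read by MTT assay (a higher number here means a weaker inhibitor, a lower number a stronger inhibitor), the highest of the two numbers in hand. Compound 1 `CNC(=O)c1ccc(Oc2cccc(NC(=S)Nc3ccc(C)cc3)c2)nc1` gives 65400 nM in this assay, and a 1.3-fold higher number from compound 1 to compound 3 (0.12 log units; within the scatter). Compound 2 `CNC(=O)c1ccc(Oc2cccc(NC(=S)Nc3ccc(C)c(C)c3)c2)nc1` reaches only the limit > 100000 nM in this assay. That limit is the limit of > 100000 nM in this assay, at which 1 of the 3 values shown sits. The steps on the aryl ring of the thiourea are thus an at least 1.5-fold higher number from compound 1 to compound 2 (0.18 log units; that floor lies within the scatter) and an at least 1.1-fold lower number from compound 2 to compound 3 (0.06 log units; that floor lies within the scatter), neither of them clearly beyond the scatter. Compound 4 `CNC(=O)c1ccc(Oc2cccc(NC(=S)Nc3ccc(Cl)cc3Cl)c2)nc1` carries the change (2,4-dichlorophenyl in place of 4-methoxyphenyl on an amide-type nitrogen). Every change on this ring so far has left the number near or beyond the top of the range, so no step beyond the scatter is expected, with a 1.1-fold higher number from compound 3 to compound 4 (0.02 log units; within the scatter) estimated. Compound 4 is therefore expected at 90000 nM, within 40000 nM to 200000 nM.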

Compound 4, half-maximal inhibitory concentration: 21600 nM
Estimate against measurement, compound 4: 4.2-fold (0.62 log units) above; the whole stated range lies above it.
By their numbers in this assay, from the lowest: compound 4; then compounds 1 and 3 (each within the scatter of the next). At a limit, above all of these: compound 2.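

Among these compounds, on the amide-type nitrogen, 2,4-dichlorophenyl gives the first steps that clearly lie beyond the scatter: a 3.9-fold lower number from compound 3 to compound 4 (0.60 log units; beyond the scatter) and a 3.0-fold lower number from compound 1 to compound 4 (0.48 log units; beyond the scatter). The step from the 3,4-dimethylphenyl analogue, an at least 4.6-fold lower number from compound 2 to compound 4 (0.66 log units; beyond the scatter), is only a floor. Compound 2 carries a limit of the assay, not a number: the limit of > 100000 nM in this assay, at which 1 of the 4 values shown sits.

From the compounds shown here alone, whether the step needs both chlorines stays open; a phenyl bearing one chlorine, or a trifluoromethyl or nitrile group in their place, would bear on this. The compounds shown also leave open whether the same step holds on a changed core.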